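Three Limits and a Fluoropyridinyl Swap at the Outer Ring

The source may hold more compounds than are shown below. What is called first, only, known or untested is meant among the compounds shown, and "the series" means these compounds.

Measured so far in a functional assay on KYSE-70 cells for antiproliferative activity against KYSE-70 cell line (Homo sapiens), read by MTT assay, with a stated time of 72 h; a lower number here means a stronger inhibitor, a higher number a weaker inhibitor:
Compound 1 `O=C(Nc1ccc(F)cc1)c1ccnc2cc(Br)ccc12`: compound 1 gives > 20000 nM, a limit of the assay.
Compound 2 `O=C(Nc1cccc(C(F)(F)F)c1)c1cc(=O)[nH]c2cc(Br)ccc12`: compound 2 gives > 20000 nM, a limit of the assay.
Compound 3 `COc1ccc(-c2ccc3c(C(=O)Nc4cccc(F)c4)cc(=O)[nH]c3c2)cc1`: compound 3 gives > 20000 nM, a limit of the assay.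

Compound 3 stands where the whole set stands: at the limit, since (the limit of > 20000 nM in this assay, at which 3 of the 3 values shown sit). Going by the values given here, no number has been reached for any of the three, so no step between measured compounds can be sized, and nothing among them separates one from another.

Compound 4 `O=C(Nc1cccc(F)c1)c1cc(=O)[nH]c2cc(-c3ccc(F)nc3)ccc12` is the compound still to be measured in this assay. It differs from compound 3 in one place: 6-fluoropyridin-3-yl in place of 4-methoxyphenyl on an aromatic carbon. Whether this change moves the result off the limit is not shown by any measured pair here, and no expectation of direction can be drawn from the three limits.

The expected step that the limit leaves unreadable from compound 3 to compound 4 is therefore set near none beyond the scatter. Compound 4 is estimated at 30000 nM, with a range from 5000 nM to 100000 nM, and the most probable outcome is that this assay again reports only a limit for compound 4.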

Compound 4, half-maximal inhibitory concentration: > 20000 nM
Compound 4 ended at the assay's limit; the forecaster's own chance of this, stated with the estimate: 80%; the middle value does not contradict the limit.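

No step from compound 3 to compound 4 can be read in this assay, since neither compound gives a number, only a limit: the limit of > 20000 nM in this assay, at which 4 of the 4 values shown sit.

The compounds shown leave open which change, if any, would bring a measured number instead of a limit.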